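Cyano in Place of Methyl on a Sub-Nanomolar Scaffold

The source may hold more compounds than are shown below. What is called first, only, known or untested is meant among the compounds shown, and "the series" means these compounds.

Three compounds share a core and were measured in an assay on isolated protein for displacement of a labelled ligand from Apoptosis regulator Bcl-2 (Homo sapiens), read by fluorescence polarization; a higher number here means a weaker inhibitor, a lower number a stronger inhibitor.
Compound 1, `CN(C)CC[C@H](CSc1ccccc1)Nc1ccc(S(=O)(=O)NC(=O)c2ccc(N3CCN(Cc4ccccc4-c4ccc(Cl)cc4)CC3)cc2)cc1C(F)(F)F`, gives < 1 nM, a limit of the assay rather than a number.
Compound 2, `Cc1cc(S(=O)(=O)NC(=O)c2ccc(N3CCN(Cc4ccccc4-c4ccc(Cl)cc4)CC3)cc2)ccc1N[C@H](CCN(C)C)CSc1ccccc1`, gives < 1 nM, again a limit.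
Compound 3, `O=C(NS(=O)(=O)c1ccc(NCCSc2ccccc2)c([N+](=O)[O-])c1)c1ccc(N2CCN(Cc3ccccc3-c3ccc(Cl)cc3)CC2)cc1`, gives < 1 nM, also a limit.

Compound 2 therefore stands at the floor of what this assay can report, alongside the other two, as the limit of < 1 nM in this assay, at which 3 of the 3 values shown sit, shows. Among the compounds with values here, the one step that would bear on it, a step that the two limits leave unreadable from compound 1 to compound 2, cannot be sized because both ends sit at that limit.

Compound 4, `CN(C)CC[C@H](CSc1ccccc1)Nc1ccc(S(=O)(=O)NC(=O)c2ccc(N3CCN(Cc4ccccc4-c4ccc(Cl)cc4)CC3)cc2)cc1C#N`, differs from compound 2 by cyano in place of methyl on an aromatic carbon. Within the data shown here, no measured step involves a cyano group, so the only guide is that every compound so far, including compound 2 with its < 1 nM, has been too potent to resolve.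

The expected step that the limit leaves unreadable from compound 2 to compound 4 is accordingly small, with no direction beyond the scatter. Compound 4 is estimated at 0.8 nM, within a range from 0.2 nM to 4 nM, with a fair chance that the assay again returns only a limit.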

Compound 4, inhibition constant: < 1 nM
Compound 4 ended at the assay's limit; the forecaster's own chance of this, stated with the estimate: 60%; the middle value lies beyond the limit too.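

Compound 4 adds no readable step, since its comparisons with compound 1 and compound 2 each join two limits of the assay: the limit of < 1 nM in this assay, at which 4 of the 4 values shown sit.

What the compounds shown leave open is how far apart their true strengths lie in this assay and so whether cyano, methyl or trifluoromethyl on that aromatic carbon makes any difference.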